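The compounds below may be only part of what the source reports. "The series", "measured", "known", "first", "only" and "open" are said of these compounds alone.

Compound 1, `CC(C)(C)c1ccc(-n2cc(-c3cn([C@H]4C[C@H](O)[C@@H](CO)O4)c(=O)[nH]c3=O)nn2)cc1`, gives 15000 nM in an ADME assay on L1210 cells (Mus musculus) for cytotoxicity, read by cell counting, with a stated time of 2 days; a lower number here means a stronger inhibitor, a higher number a weaker inhibitor. Compound 2, `CC(C)c1ccc(-n2nncc2-c2cn([C@H]3C[C@H](O)[C@@H](CO)O3)c(=O)[nH]c2=O)cc1`, is built on the same core with the ring attachment arranged differently. In this assay compound 2 reaches only the limit of the measurement, > 200000 nM, and no number stands for it; this is the limit of > 200000 nM in this assay, at which 1 of the 2 values shown sits. Compound 3, `O=c1[nH]c(=O)n([C@H]2C[C@H](O)[C@@H](CO)O2)cc1-c1cnnn1-c1ccc(Oc2ccccc2)cc1`, carries phenoxy in place of isopropyl on an aromatic carbon. Going by the values given here, no measured step of this kind exists to lean on, so the expected step is an at least 1.3-fold lower number from compound 2 to compound 3 (0.12 log units; that floor lies within the scatter), a modest change toward stronger inhibition that may not exceed the usual scatter. Compound 3 is therefore expected at 150000 nM, between 30000 nM and 400000 nM.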

Compound 3, half-maximal inhibitory concentration: 134000 nM
Compound 3: the middle estimate sits 1.1-fold (0.05 log units) above what was measured; measured number inside the range.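

In this assay, phenoxy in place of isopropyl on this aromatic carbon gives an at least 1.4-fold lower number from compound 2 to compound 3 (0.17 log units; that floor lies within the scatter). Compound 3 therefore has a real number at this position, where compound 2 has none. The true size of the step stays unknown, and it can be given only as a minimum because compound 2 is held at a limit: the limit of > 200000 nM in this assay, at which 1 of the 3 values shown sits.

The compounds shown leave open how an amine or a longer alkyl chain would read at this position. They also leave open whether phenoxy would give a similar step on the ring arrangement of compound 1.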